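The source may report more compounds than this note shows. Statements on the series, on what has been measured and on what is new or still open speak of the compounds shown alone.

Compound 1 `Cc1c(Cc2c(Cl)cccc2Cl)nc(SCC(=O)c2ccccc2)[nH]c1=O`: > 60000 nM
Compound 2 `Cc1c(Cc2c(Cl)cccc2Cl)nc(SCC(=O)c2ccc(F)cc2)[nH]c1=O`: > 57000 nM
Compound 3 `CC(C)c1c(Cc2c(Cl)cccc2Cl)nc(SCC(=O)c2ccccc2)[nH]c1=O`: > 56000 nM

These three compounds share a core and were tested in an ADME assay on MT4 cells (Homo sapiens) for cytotoxicity, read by MTT assay; on this read-out higher numbers stand for lower toxicity in this test and lower numbers for higher toxicity in this test. For compound 1 the value is a limit of the assay, not a number (the limit of > 60000 nM in this assay, at which 1 of the 3 values shown sits). For compound 2 the value is likewise a limit (the limit of > 57000 nM in this assay, at which 1 of the 3 values shown sits). For compound 3 the value is also a limit (the limit of > 56000 nM in this assay, at which 1 of the 3 values shown sits). The step that the two limits leave unreadable from compound 1 to compound 2 corresponds to the change (fluoro in place of hydrogen on an aromatic carbon). The cores of compound 1 and compound 3 differ by isopropyl in place of methyl on an aromatic carbon, giving the step that the two limits leave unreadable from compound 1 to compound 3. Compound 4 `CC(C)c1c(Cc2c(Cl)cccc2Cl)nc(SCC(=O)c2ccc(F)cc2)[nH]c1=O` is not yet measured; it differs from compound 3 by fluoro in place of hydrogen on an aromatic carbon, the same change as between compound 1 and compound 2, at the same place. That change left compound 1 and compound 2 both at limits, and compound 3 itself stands at a limit (the limit of > 56000 nM in this assay, at which 1 of the 3 values shown sits); on this rests the expectation of a small step that the limit leaves unreadable from compound 3 to compound 4. Compound 4 is expected to give 60000 nM, most likely again only a limit.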

Compound 4, half-maximal cytotoxic concentration: > 54000 nM
Compound 4: only a limit was reported (the forecaster's own chance of this, stated with the estimate: 85%); the middle value does not contradict the limit.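

Compound 2, compound 3 and compound 4 all stand only at limits, not at numbers, and the steps to compound 4 from compound 2 and compound 3 cannot be read. The compounds shown leave open at what concentration any of them becomes toxic to these cells.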